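This account rests on a few compounds, and the source may have more. Where it says the series, first, only, none or still open, it means among the compounds named here.

Measured compounds and their values:

Compound 1, `Cc1ncc([N+](=O)[O-])n1CC(O)CSC(=S)N1CCCCC1`, in a toxicity assay on HeLa cells (Homo sapiens) for cytotoxicity, read by MTT assay, with a stated time of 24 h (a higher number here means a weaker inhibitor, a lower number a stronger inhibitor), compound 1 gives 1400000 nM.
Compound 2, `CCN1CCN(CC(O)Cn2c([N+](=O)[O-])cnc2C)CC1`, in this assay compound 2 gives 4940000 nM.
Compound 3, `COc1ccccc1N1CCN(CC(O)Cn2c([N+](=O)[O-])cnc2C)CC1`, in this assay compound 3 gives 4390000 nM.

Compound 3 stands second highest of the three numbers. Its nearest neighbour is compound 2, and the two sit within the usual scatter of each other, so no order between them can be read. Compound 1, the furthest of the three, gives a lower number, and that gap lies beyond the scatter.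

Compound 4, `Cc1ncc([N+](=O)[O-])n1CC(O)CN1CCN(c2ncccn2)CC1`, is not yet measured. It differs from compound 3 in one place: pyrimidin-2-yl in place of 2-methoxyphenyl on an amine nitrogen in a ring. Within the data shown here, one measured step bears on this change, as it exchanges the group on the same ring nitrogen: a 1.1-fold lower number from compound 2 to compound 3 (0.05 log units; within the scatter). That exchange of ethyl for 2-methoxyphenyl left the number essentially where it was. On this single precedent, the further exchange to pyrimidin-2-yl is expected to produce no step beyond the scatter in this assay, so compound 4 is estimated at 4500000 nM, with a range from 2000000 nM to 10000000 nM. The step this estimate implies is expected to be a 1.0-fold higher number from compound 3 to compound 4 (0.01 log units; within the scatter).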

Compound 4, half-maximal inhibitory concentration: 3930000 nM
Estimate against measurement, compound 4: 1.1-fold (0.06 log units) above, within the range that was stated.
By their numbers in this assay, from the lowest: compound 1; then compounds 4, 3 and 2 (each within the scatter of the next).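

In this assay, the exchange of 2-methoxyphenyl for pyrimidin-2-yl on the amine nitrogen gives a 1.1-fold lower number from compound 3 to compound 4 (0.05 log units; within the scatter), and the exchange of ethyl for pyrimidin-2-yl gives a 1.3-fold lower number from compound 2 to compound 4 (0.10 log units; within the scatter). Among these compounds, the earlier compounds offered only one exchange at this nitrogen, whereas three groups can now be compared there, including a six-membered aromatic ring with 2 hetero atoms as well as one of carbon only, and no step among them lies beyond the scatter. Nothing in the data given explains why the number holds across these three groups.

From the compounds shown here alone, it remains open whether a group of another kind on this ring nitrogen, such as a carboxylic acid, a primary amine or a longer chain, would give a step beyond the scatter. Against compounds 2, 3 and 4, compound 1, at 1400000 nM, differs in more than one place, so its value cannot be tied to any single part of its structure, and the role of the other parts of the shared core remains untested by these compounds.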